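A few compounds are considered here, and "the series" means these few. Any claim that something is new, unique, unknown or untested is made for them only; others in the source may bear on it.

Measured compounds: compound 1 `COc1cc(C=C(C(=O)/C=C/c2cccc(OC)c2OC)C(=O)/C=C/c2cccc(OC)c2OC)cc(Br)c1O`, 360 nM; compound 2 `COc1cc(C=C(C(=O)/C=C/c2cccc(OC)c2OC)C(=O)/C=C/c2cccc(OC)c2OC)cc(OC)c1O`, 460 nM; compound 3 `COc1ccc(/C=C/C(=O)C(=Cc2cc(Br)c(O)c(OC)c2)C(=O)/C=C/c2ccc(OC)cc2OC)c(OC)c1`, 2600 nM.

All three were tested in a functional assay on MCF7 cells (Homo sapiens) for antiproliferative activity, read by sulforhodamine B assay, with a stated time of 48 h; a lower number here means a stronger inhibitor, a higher number a weaker inhibitor. Compound 1 and compound 2 share one core, and the change between them, (methoxy in place of bromo on an aromatic carbon), gives a 1.3-fold higher number from compound 1 to compound 2 (0.11 log units; within the scatter). Compound 3 has the same atoms as compound 1, joined differently; the difference between the two cores is not broken down here. Compound 3 stands highest of the three, beyond the scatter from both compound 2 and compound 1. Compound 4 `COc1ccc(/C=C/C(=O)C(=Cc2cc(OC)c(O)c(OC)c2)C(=O)/C=C/c2ccc(OC)cc2OC)c(OC)c1` has not been measured. It differs from compound 3 by methoxy in place of bromo on an aromatic carbon, the same change as that from compound 1 to compound 2, at an identically described place. Because the step of a 1.3-fold higher number from compound 1 to compound 2 (0.11 log units; within the scatter) lies within the scatter, a step of similar size is expected here. Compound 4 is thus expected to shift by a 1.3-fold higher number from compound 3 to compound 4 (0.12 log units; within the scatter). The estimate for compound 4 is 3400 nM, in the range 1500 nM to 7500 nM.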

Compound 4, half-maximal inhibitory concentration: 970 nM
Estimate against measurement, compound 4: 3.5-fold (0.54 log units) above; the whole stated range lies above it.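

In this assay the exchange of bromo for methoxy gives a 2.7-fold lower number from compound 3 to compound 4 (0.43 log units; beyond the scatter) and does not carry over at the same size between the two cores: the same change on two cores in this assay, a 1.3-fold higher number (0.11 log units; within the scatter) from compound 1 to compound 2 and a 2.7-fold lower number (0.43 log units; beyond the scatter) from compound 3 to compound 4, 3.4-fold (0.53 log units) apart, beyond the scatter of two such steps. A step read on one core of this series was therefore not a reliable guide to the same change on the other, at least for these two pairs. The two pairs do not show which difference between the cores is responsible, nor do they give a rule for any further core.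

The compounds shown compare only bromo and methoxy at this place, ortho to a hydroxy group. As far as these compounds go, how an amine, a carboxylic acid or a longer alkoxy chain would behave there on either core remains open.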